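Emax notes: heteroaryl swap on the piperidine nitrogen

This account rests on a few compounds, and the source may have more. Where it says the series, first, only, none or still open, it means among the compounds named here.

Two compounds have numbers in a functional assay on CHO-K1 cells for agonist activity at Glucose-dependent insulinotropic receptor (Mus musculus), read by HTRF and cAMP accumulation, with a stated time of 30 min (on this read-out lower numbers stand for smaller maximal responses and higher numbers for larger maximal responses), so far. Compound 1, `CC(C)(C)OC(=O)N1CCC(CCCNc2ccc3c(c2)CCS3(=O)=O)CC1`, gives 83% in this assay. Compound 2, `CCc1cnc(N2CCC(CCCNc3ccc4c(c3)OCC4=O)CC2)nc1`, gives 98% in this assay, the higher of the two numbers, and its gap to compound 1 lies beyond the scatter. Among the measured compounds shown here, the two compounds differ in more than one place, so no single step between them is set down; their two values are all that can be compared.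

Compound 3, `CC(C)c1nnc(N2CCC(CCCNc3ccc4c(c3)OCC4=O)CC2)o1`, has not been measured in this assay. Against compound 2 the change is 5-isopropyl-1,3,4-oxadiazol-2-yl in place of 5-ethylpyrimidin-2-yl on an amine nitrogen in a ring. The rest of the structure, including the three-carbon linker and the bicyclic core of compound 2, is kept.

For the measured compounds named here, no step between measured compounds bears on this change. Since the two measured compounds both reach a large maximal response, compound 3 is expected to stay near that level, with the estimated step of a number 6 percentage points lower from compound 2 to compound 3 (within the scatter) small and, if anything, downward, possibly within the scatter. The estimate for compound 3 in this assay is 92%, with a range from 75% to 105%.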

Compound 3, largest response reached (Emax), in percent of the reference or control that the assay uses: 88%
Estimate against measurement, compound 3: 4 percentage points above, within the range that was stated.
By their numbers in this assay, from the lowest: compounds 1, 3 and 2 (each within the scatter of the next, the first and the last beyond it).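

Swapping 5-ethylpyrimidin-2-yl for 5-isopropyl-1,3,4-oxadiazol-2-yl on the amine nitrogen in a ring gives the first single-place reading for this position in this assay and amounts to a number 10 percentage points lower from compound 2 to compound 3 (within the scatter) in the series. The maximal response therefore does not separate a six-membered aromatic ring with 2 hetero atoms from a five-membered aromatic ring with 3 hetero atoms when the rest of the structure is kept, although this holds for this one pair only. No supporting measurement accompanies the pair, so the result rests on the two maximal responses alone, with nothing to account for it.

The step changes the ring and its alkyl substituent together, so the share of each stays unresolved; 5-ethyl-1,3,4-oxadiazol-2-yl or 5-isopropylpyrimidin-2-yl would separate the two. As far as these compounds go, how far the tolerance at this nitrogen extends also remains open, for instance to a pyridin-2-yl group or to a ring carrying a carboxylic acid or an amine in place of the alkyl substituent.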